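The source may report more compounds than this note shows. Statements on the series, on what has been measured and on what is new or still open speak of the compounds shown alone.

Measured set:
- compound 1, `COc1ncc(-c2ccc3c(c2)N(c2ccc(C)cc2)C(=O)CO3)cc1NS(=O)(=O)c1ccc(F)cc1`: 15400 nM
- compound 2, `O=C1COc2ccc(-c3cccc(NS(=O)(=O)c4ccc(F)cc4)c3)cc2N1C1CC1`: limit only, > 40000 nM
- compound 3, `COc1cccc(N2C(=O)COc3ccc(-c4cnc(Cl)c(NS(=O)(=O)c5ccc(F)cc5)c4)cc32)c1`: limit only, > 40000 nM

Among the measured compounds shown here, in a functional assay on MCF7 cells (Homo sapiens) for antiproliferative activity, read by MTT assay, with a stated time of 72 h (on this read-out lower numbers stand for stronger inhibition and higher numbers for weaker inhibition), compound 1 gives 15400 nM, the only plain number. For compound 2 the read-out is a limit of the assay, > 40000 nM, and not a number. Compound 3 likewise sits at a limit, > 40000 nM, so its position on the scale is known only as weaker than that bound. Two of the three values thus rest at the limit of > 40000 nM in this assay, at which 2 of the 3 values shown sit, which leaves the series with little to anchor a step.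

Compound 4, `O=C1COc2ccc(-c3cnc(Cl)c(NS(=O)(=O)c4ccc(F)cc4)c3)cc2N1c1ccc(F)cc1`, is not yet measured in this assay. It differs from compound 3 in one place: 4-fluorophenyl in place of 3-methoxyphenyl on an amide-type nitrogen in a ring. For the measured compounds named here, because compound 3 is known only as the limit > 40000 nM, no measured step sets a scale for this change; nothing in the data marks the new group as one that would move the value beyond the scatter. The step from compound 3 to compound 4 is expected to be small or none beyond the scatter, with an at least 1.1-fold lower number from compound 3 to compound 4 (0.05 log units; that floor lies within the scatter) taken as roughly flat. For compound 4 the expected value is 35000 nM, within 12000 nM to 90000 nM, with a fair chance that only a limit is reported.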

Compound 4, half-maximal inhibitory concentration: 32600 nM
Beside the measured number, compound 4's estimate is 1.1-fold (0.03 log units) above it; the measured number falls inside the stated range.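

Among the compounds shown here, at this position, the amide-type nitrogen in a ring, this assay gives an at least 1.2-fold lower number from compound 3 to compound 4 (0.08 log units; that floor lies within the scatter) on exchanging 3-methoxyphenyl for 4-fluorophenyl, the first step that can be read at all. The step shows only that a 4-fluorophenyl on this nitrogen yields a plain number, and its floor does not establish a change beyond the scatter. For compound 3 the value remains a limit, > 40000 nM, and the real size of the step stays unknown because the read-out ends there: the limit of > 40000 nM in this assay, at which 2 of the 4 values shown sit.

Still open, from the compounds shown here alone, is how the value responds to other groups on this nitrogen, such as a longer alkyl chain or a phenyl carrying an amine or a carboxylic acid. Also open, going by these compounds, is whether the same exchange would give a step of similar size on the core of compound 1.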